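Chloro in Place of Trifluoromethyl on a Biaryl Amide

The source may hold more compounds than are shown below. What is called first, only, known or untested is meant among the compounds shown, and "the series" means these compounds.

Measured compounds:
compound 1 `Cc1cccc(C(=O)Nc2ccc3c(c2)CC(NS(=O)(=O)c2ccccc2)C3)c1-c1ccc(Cl)cc1` — 2.4 nM
compound 2 `COC(=O)NCC1Cc2ccc(NC(=O)c3cccc(C)c3-c3ccc(C(F)(F)F)cc3)cc2C1` — 4.1 nM

Both compounds were tested in an assay for inhibition of apolipoprotein B-100 (Homo sapiens), tested at 100 nM; on this read-out lower numbers stand for stronger inhibition and higher numbers for weaker inhibition. Compound 1 gives 2.4 nM in this assay, and compound 2 gives 4.1 nM. Of the two numbers shown, compound 2 stands at the higher one; its nearest neighbour is compound 1, whose number lies within the scatter of that of compound 2, so no order between the two can be claimed. Within the data shown here, compound 1 and compound 2 differ in more than one place, and no single step connects them.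

Compound 3 `COC(=O)NCC1Cc2ccc(NC(=O)c3cccc(C)c3-c3ccc(Cl)cc3)cc2C1` has not yet been measured. It differs from compound 2 in one place: chloro in place of trifluoromethyl on an aromatic carbon. Among the measured compounds shown here, no step between measured compounds carries this change alone. Compound 1 also carries a chloro group, yet it differs from compound 2 in more than this one respect, so it can only hint at the outcome.

Because compound 1 gives 2.4 nM while bearing a chloro group, the step from compound 2 to compound 3 is expected to be small, if anything toward a lower number, and not beyond the scatter: a 1.2-fold lower number from compound 2 to compound 3 (0.07 log units; within the scatter). Compound 3 is estimated at 3.5 nM, with a range from 1.5 nM to 8 nM.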

Compound 3, half-maximal inhibitory concentration: 8.7 nM
Compound 3: the middle estimate sits 2.5-fold (0.40 log units) below what was measured; measured number above the stated range.
By their numbers in this assay, from the lowest: compounds 1 and 2 (each within the scatter of the next); then compound 3.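

In this assay, the change from 4-(trifluoromethyl)phenyl to 4-chlorophenyl is not silent: it gives a 2.1-fold higher number from compound 2 to compound 3 (0.33 log units; beyond the scatter), so this position responds to the exchange even though the step is modest. With the 4-chlorophenyl group held constant, ((methoxycarbonyl)amino)methyl in place of (phenylsulfonyl)amino on a saturated ring carbon gives a 3.6-fold higher number from compound 1 to compound 3 (0.56 log units; beyond the scatter), which shows that the low number of compound 1 does not go with the chloro group alone. Compound 1 and compound 2 differ in both of these places and still lie within the scatter of each other, so the two single changes, each beyond the scatter, cancel in the numbers when taken together.

Nothing shown accounts for either step. Going by these compounds, whether the trifluoromethyl group would also give a different number from the chloro group on a compound carrying the (phenylsulfonyl)amino group stays open, as does the outcome at this position with another group, such as a fluoro, methyl or methoxy group.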